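Notes: carboxy replaced by 2-cyanoethyl on the shared core

This account rests on a few compounds, and the source may have more. Where it says the series, first, only, none or still open, it means among the compounds named here.

Compound 1 `O=C(O)c1cc(=O)oc2cc(OCc3cccc(Cl)c3)ccc12` is the weakest of the three measured compounds, with every step away from it beyond the scatter. In an assay on brain (strain Sprague-Dawley) for inhibition of Amine oxidase [flavin-containing] B (Rattus norvegicus), read by spectrophotometry (a higher number here means a weaker inhibitor, a lower number a stronger inhibitor), compound 1 gives 100000 nM. Its nearest neighbour is compound 3 `O=c1cc(CCBr)c2ccc(OCc3cccc(Cl)c3)cc2o1`, which in this assay gives 32.4 nM; furthest from it is compound 2 `O=c1cc(CCO)c2ccc(OCc3cccc(Cl)c3)cc2o1`, which gives 7.41 nM. Both departures from the carboxy compound are large: a 13000-fold lower number from compound 1 to compound 2 (4.13 log units; beyond the scatter) and a 3100-fold lower number from compound 1 to compound 3 (3.49 log units; beyond the scatter). Between the two chain compounds the difference is modest: a 4.4-fold higher number from compound 2 to compound 3 (0.64 log units; beyond the scatter).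

Compound 4 `N#CCCc1cc(=O)oc2cc(OCc3cccc(Cl)c3)ccc12` has not yet been measured. Against compound 1 the change is 2-cyanoethyl in place of carboxy on an aromatic carbon. Going by the values given here, the steps that bear on it are the two that remove the carboxy group and install a chain on the same aromatic carbon, and both were large in the same direction. The 2-cyanoethyl chain, like 2-bromoethyl and unlike 2-hydroxyethyl, carries no hydrogen-bond donor, so the step from compound 1 to compound 3 is taken as the closer guide, with the step to compound 2 marking the upper end of what the change could deliver. A large drop in this assay is therefore expected, a 5000-fold lower number from compound 1 to compound 4 (3.70 log units; beyond the scatter). For compound 4 the estimate in this assay is 20 nM, within a range of 3 nM to 150 nM.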

Compound 4, half-maximal inhibitory concentration: 28.8 nM
Compound 4: the middle estimate sits 1.4-fold (0.16 log units) below what was measured; measured number inside the range.
By their numbers in this assay, from the lowest: compound 2; then compounds 4 and 3 (each within the scatter of the next); then compound 1.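

Notes on the chain end: in this assay a third chain, 2-cyanoethyl, replaces carboxy on this aromatic carbon opposite the ring oxygen and again gives a large gain (a 3500-fold lower number from compound 1 to compound 4 (3.54 log units; beyond the scatter)), so across the three chains shown the gain does not rest on one particular end group. Cyano and bromo at the end of the chain cannot be told apart (a 1.1-fold lower number from compound 3 to compound 4 (0.05 log units; within the scatter)), which shows that this position accepts a nitrile, with its triple bond, as readily as a bromo group. Hydroxy keeps a modest lead over cyano (a 3.9-fold higher number from compound 2 to compound 4 (0.59 log units; beyond the scatter)), so compound 2 still stands apart from compound 3 and compound 4, and the chain end does have some influence on the number, though far less than removing carboxy from the shared core. Nothing shown gives a reason for these differences.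

Still open, from the compounds shown here alone, is whether the large gain comes from losing the carboxylic acid itself or from gaining a chain, which a carboxylic acid held at the end of a longer chain would separate. Also open, going by these compounds, is how an amine or an amide at the chain end, or a shorter or longer chain carrying the nitrile, would compare with compound 4.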